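The source may hold more compounds than are shown below. What is called first, only, known or untested is meant among the compounds shown, and "the series" means these compounds.

Measured so far:
- compound 1, `CCCCCn1c(-c2ccccc2)nc2c(N)ccnc21`, > 200000 nM
- compound 2, `CCCCCn1c(-c2ccco2)nc2c(N)ccnc21`, > 200000 nM

In an assay on isolated protein for inhibition of high affinity 3',5'-cyclic-AMP phosphodiesterase 7A (Homo sapiens), read by cAMP accumulation, with a stated time of 20 min (on this read-out lower numbers stand for stronger inhibition and higher numbers for weaker inhibition), compound 1 reaches only a limit of the assay, > 200000 nM. Compound 2 likewise reaches only a limit, > 200000 nM. Both values therefore sit at the limit of > 200000 nM in this assay, at which 2 of the 2 values shown sit, so the step that the two limits leave unreadable from compound 1 to compound 2 cannot be read, and compound 2 stands nowhere more precise than at that limit.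

Compound 3, `CCCCCn1c(-c2ccco2)nc2c(N(C)CCCO)ccnc21`, differs from compound 2 in one place: (3-hydroxypropyl)(methyl)amino in place of amino on an aromatic carbon. Within the data shown here, the only measured step, from compound 1 to compound 2, concerns the aromatic carbon carrying the phenyl or furan-2-yl group, not the carbon carrying the amino group, and its size is unreadable; nothing measured here speaks directly to the change from amino to (3-hydroxypropyl)(methyl)amino. The expectation for compound 3 can therefore only start from the limit shown for compound 2 and allow room on either side of it.

On that basis compound 3 is estimated at 150000 nM in this assay, with a range from 15000 nM to 800000 nM, which corresponds to an expected step of an at least 1.3-fold lower number from compound 2 to compound 3 (0.12 log units; that floor lies within the scatter).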

Compound 3, half-maximal inhibitory concentration: 18900 nM
The estimate for compound 3 lay 7.9-fold (0.90 log units) above the measured number; low and high end bracket the measured number.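

Among these compounds, replacing amino with (3-hydroxypropyl)(methyl)amino on the aromatic carbon opposite the ring nitrogen gives an at least 10-fold lower number from compound 2 to compound 3 (1.02 log units; beyond the scatter) in this assay, the first step whose size can be read, even if only as a minimum. The earlier step, furan-2-yl in place of phenyl, cannot be read, so this carbon is the first place shown where a change in the group goes with a clear change in the read-out. Compound 3, at 18900 nM, is also the only compound here with a measured number rather than a limit: the limit of > 200000 nM in this assay, at which 2 of the 3 values shown sit.

Going by these compounds, what remains open is which part of the new group goes with the step, the methyl or the 3-hydroxypropyl chain, a question that a plain methylamino or a 3-hydroxypropylamino group on the same carbon would help to settle. Also open, on these data alone, are whether a longer chain or a carboxylic acid at the end of the chain would lower the number further, and whether the same group would give a similar step with phenyl in place of furan-2-yl.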